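The source may hold more compounds than are shown below. What is called first, only, known or untested is meant among the compounds shown, and "the series" means these compounds.

Values in a functional assay on PC-3 cells (Homo sapiens) for cytotoxicity, read by MTT assay, with a stated time of 72 h (a lower number here means a stronger inhibitor, a higher number a weaker inhibitor), for the measured compounds:
Compound 1 `COc1cc2ncnc(Nc3ccc(F)c(Cl)c3)c2cc1NC(=O)N/N=C/c1ccc(C#N)cc1` gives 36500 nM
Compound 2 `COc1cc2ncnc(Nc3ccc(F)c(Cl)c3)c2cc1NC(=O)N/N=C/c1cccc(Cl)c1Cl` gives 24400 nM
Compound 3 `COc1ccc(/C=N/NC(=O)Nc2cc3c(Nc4ccc(F)c(Cl)c4)ncnc3cc2OC)cc1` gives 16500 nM

Compound 3 stands clear of only one of the other two, as the data show a 2.2-fold lower number from compound 1 to compound 3 (0.34 log units; beyond the scatter) alongside a 1.5-fold lower number from compound 2 to compound 3 (0.17 log units; within the scatter) in this set.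

Compound 4 `COc1cc2ncnc(Nc3ccc(F)c(Cl)c3)c2cc1NC(=O)N/N=C/c1ccc(OC)c(OC)c1OC` has not yet been measured. It differs from compound 3 by 2,3,4-trimethoxyphenyl in place of 4-methoxyphenyl on a carbon with a double bond to nitrogen and so carries 2,3,4-trimethoxyphenyl in place of 4-methoxyphenyl on a carbon with a double bond to nitrogen.

Within the data shown here, no measured pair makes this exact change, so the nearest evidence comes from the other swaps of the group on that same carbon. Two of these stay small, namely a 1.5-fold lower number from compound 1 to compound 2 (0.17 log units; within the scatter) and a 1.5-fold lower number from compound 2 to compound 3 (0.17 log units; within the scatter) in the data. The largest, a 2.2-fold lower number from compound 1 to compound 3 (0.34 log units; beyond the scatter) on the record, is only modest. From the compounds shown here alone, on that basis no step beyond the scatter is expected in this assay in either direction, although the effect of the added methoxy groups remains untested in this set. The expected step is a 1.1-fold lower number from compound 3 to compound 4 (0.04 log units; within the scatter) by this estimate. For compound 4 the estimated value is 15000 nM within an expected range of 6000 nM to 38000 nM for a single measurement.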

Compound 4, half-maximal inhibitory concentration: 29300 nM
For compound 4 the middle estimate is 2.0-fold (0.29 log units) below the measured one; measured number inside the range.
By their numbers in this assay, from the lowest: compounds 3, 2, 4 and 1 (each within the scatter of the next, the first and the last beyond it).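

In this assay, replacing 4-methoxyphenyl with 2,3,4-trimethoxyphenyl on the carbon with a double bond to nitrogen gives a step that cannot be told from the scatter (a 1.8-fold higher number from compound 3 to compound 4 (0.25 log units; within the scatter)). Compound 4 is equally close to the compounds carrying the other two groups (a 1.2-fold higher number from compound 2 to compound 4 (0.08 log units; within the scatter); a 1.2-fold lower number from compound 1 to compound 4 (0.10 log units; within the scatter)), so methoxy groups on this ring do not by themselves set a compound apart from compound 1, and compound 3 remains the only one that stands clear of it (a 2.2-fold lower number from compound 1 to compound 3 (0.34 log units; beyond the scatter)). Nothing available accounts for the separation of compound 3 from compound 1, or for the absence of such a separation for compound 4.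

From the compounds shown here alone, all four compounds carry a substituted phenyl ring at this position, so it remains open whether an amine or a carboxylic acid on that ring, or a longer chain in place of the ring, would move the number beyond the scatter. It also remains open whether each methoxy group of 2,3,4-trimethoxyphenyl matters on its own, as no compound shown carries only part of that pattern.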